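The source may hold more compounds than are shown below. What is called first, only, known or untested is meant among the compounds shown, and "the series" means these compounds.

Measured so far in an assay on RPMI-8226 cells for antagonist activity at P2X purinoceptor 7 (Homo sapiens), read by calcium flux; a lower number here means a stronger inhibitor, a higher number a weaker inhibitor:
- compound 1 `O=c1[nH]c2ccccc2n1CCCN1CCN(S(=O)(=O)c2ccc([N+](=O)[O-])cc2)CC1`: compound 1 gives > 10000 nM, a limit of the assay rather than a number.
- compound 2 `O=c1[nH]c2ccccc2n1CCCN1CCC(C(O)(c2ccccc2)c2ccccc2)CC1`: compound 2 gives 7500 nM.
- compound 3 `O=c1[nH]c2ccccc2n1CCCCN1CCN(C(c2ccccc2)c2ccccc2)CC1`: compound 3 gives 180 nM.

Compound 3 holds the lowest of the two numbers; compound 2 sits at a higher number, and that gap lies beyond the scatter. For compound 1 only a limit is known: the limit of > 10000 nM in this assay, at which 1 of the 3 values shown sits. Within the data shown here, no pair of measured compounds differs in a single place, so the next change has no measured precedent. Compound 4 `N#Cc1cn(CCCCN2CCN(C(c3ccccc3)c3ccccc3)CC2)c2ccccc12` differs from compound 3 by a group of 11 heavy atoms (9 carbon, 2 nitrogen; one five-membered aromatic ring with 1 hetero atom, one six-membered aromatic ring of carbon only) in place of a group of 10 heavy atoms (7 carbon, 2 nitrogen, 1 oxygen; one five-membered aromatic ring with 2 hetero atoms, one six-membered aromatic ring of carbon only), on a saturated chain carbon, four bonds along the chain from an amine nitrogen in a ring. The step from compound 3 to compound 4 is expected to be a 1.9-fold higher number from compound 3 to compound 4 (0.29 log units; within the scatter), a small shift toward a weaker inhibitor, close to the scatter. Compound 4 is estimated at 350 nM in this assay, with a range from 90 nM to 1400 nM.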

Compound 4, half-maximal inhibitory concentration: 1500 nM
Estimate against measurement, compound 4: 4.3-fold (0.63 log units) below, outside the stated range (above it).
By their numbers in this assay, from the lowest: compound 3; then compound 4; then compound 2. At a limit, above all of these: compound 1.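

At the place on a saturated chain carbon, four bonds along the chain from an amine nitrogen in a ring, this exchange gives an 8.3-fold higher number from compound 3 to compound 4 (0.92 log units; beyond the scatter) in this assay and so shows that the series does not tolerate every bicyclic replacement there. The hydrogen-bond donor of the leaving group is gone and a nitrile enters, yet this single step cannot separate those differences. Nothing measured here accounts for the step.

Open, from the compounds shown here alone, is whether the nitrile itself or the change of ring drives the loss. An amide in place of the nitrile, or a longer chain, would bear on that.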